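The compounds below may be only part of what the source reports. "The series", "measured", "known", "first", "only" and "open" are said of these compounds alone.

Three compounds of this series have numbers in a functional assay on CCRF-CEM cells (Homo sapiens) for cytotoxicity, read by MTT assay, with a stated time of 72 h; a lower number here means a stronger inhibitor of growth, a higher number a weaker inhibitor of growth. Compound 1 `CC(C)COC(=O)Nc1ccc([Se][Se]c2ccc(NC(=O)OCC(C)C)cc2)cc1` gives 39800 nM. Compound 2 `CCCOC(=O)Nc1ccc([Se]C#N)cc1` gives 38400 nM. Compound 3 `CCCCCCOC(=O)Nc1ccc([Se][Se]c2ccc(NC(=O)OCCCCCC)cc2)cc1` gives 34400 nM. Compound 2 stands within the scatter of both others: its number sits close to that of compound 1 and to that of compound 3, so the three cannot be told apart in this assay. Compound 4 `CCCCCCOC(=O)Nc1ccc([Se]C#N)cc1` is not yet measured; it differs from compound 2 by propyl in place of hydrogen on a saturated chain carbon, three bonds along the chain from an oxygen next to a carbonyl group. Among the measured compounds shown here, no step between measured compounds that differ in one place is known, so the size of this change cannot be read from a neighbour; the closeness of compound 1 and compound 3, which carry differing chains, gives no sign of movement. The expected step is a 1.0-fold lower number from compound 2 to compound 4 (0.02 log units; within the scatter), not beyond the scatter. Compound 4 is estimated at 37000 nM, with a range from 15000 nM to 90000 nM.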

Compound 4, concentration for total growth inhibition: 46200 nM
Compound 4: the middle estimate sits 1.2-fold (0.10 log units) below what was measured; the measured number falls inside the stated range.
By their numbers in this assay, from the lowest: compounds 3, 2, 1 and 4 (each within the scatter of the next).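

In this assay, this position now has its first one-place step: propyl in place of hydrogen on a saturated chain carbon, three bonds along the chain from an oxygen next to a carbonyl group, gives a 1.2-fold higher number from compound 2 to compound 4 (0.08 log units; within the scatter) and so does not resolve compound 2 from compound 4. Within this pair, the position takes the hexyl chain with no change that can be told from scatter. No measurement on hand accounts for this. Going by these compounds, whether a longer chain, or an amine or a carboxylic acid at the end of this chain, would give a step beyond the scatter remains open.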